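The compounds below may be only part of what the source reports. "The series", "measured", "known", "first", "only" and "open" are said of these compounds alone.

Working notes on the series. Compound 1 `CSc1nc(NCCCc2ccccc2)c2ccccc2n1` was tested in a functional assay on HT-29 cells (Homo sapiens) for cytotoxicity, read by MTT assay, with a stated time of 72 h (a lower number here means that less compound is tolerated, a higher number that more compound is tolerated), and gave > 100000 nM, which is a limit of the assay and not a number. Compound 2 `CSc1nc(NCc2ccccc2)c2ccccc2n1` shares the core of compound 1; in this assay compound 2 gave > 100000 nM, again a limit rather than a measured value. Compound 2 therefore stands at the ceiling of what has been recorded: the limit of > 100000 nM in this assay, at which 2 of the 2 values shown sit. Going by the values given here, with both results sitting at that limit, no step between measured compounds can be read and no size of effect is known for any change made so far. Compound 3 `CSc1nc(NCCCCCO)c2ccccc2n1` carries 4-hydroxybutyl in place of phenyl on a saturated chain carbon bound to a nitrogen on an aromatic ring. Without any measured step to lean on, the step expected is a step that the limit leaves unreadable from compound 2 to compound 3, that is, nothing beyond the scatter. For compound 3 the estimate is 150000 nM, with a range from 60000 nM to 500000 nM, and the result is expected most likely to be reported again only as a limit.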

Compound 3, concentration lethal to 50% of the cells: > 100000 nM
Compound 3 was reported as a limit; the forecaster's own chance of this, stated with the estimate: 85%; the middle value does not contradict the limit.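

No step can be read from compound 2 or compound 1 to compound 3 in this assay, since all three results are limits and not numbers: the limit of > 100000 nM in this assay, at which 3 of the 3 values shown sit.

The compounds shown leave open whether replacing phenyl with 4-hydroxybutyl changes the read-out at all, and by how much.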